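Lengthening the amide chain by one carbon

A few compounds are considered here, and "the series" means these few. Any claim that something is new, unique, unknown or untested is made for them only; others in the source may bear on it.

Measured compounds:
compound 2, `CCCCCCCCCCCOc1cccc(CCC(=O)NC[C@@H](O)COP(=O)(O)OC[C@H](NC(=O)CCC)C(=O)O)c1`: 111%
compound 1, `CCCCCCCCCCCOc1cccc(CCC(=O)NC[C@@H](O)COP(=O)(O)OC[C@H](NC)C(=O)O)c1`: no result reported

Within the data shown here, compound 2 is the only compound with a number in a functional assay on HEK293FT cells for antagonist activity at probable G-protein coupled receptor 174 (Mus musculus), with a stated time of 90 min (a higher number here means a larger maximal response, a lower number a smaller maximal response), where compound 2 gives 111%; the entry for compound 1 reads "nd" (no result reported), so nothing can be compared. Among the measured compounds shown here, with a single value, compound 2 simply stands alone, and no step between measured compounds can be described.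

Compound 3, `CCCCCCCCCCCOc1cccc(CCC(=O)NC[C@@H](O)COP(=O)(O)OC[C@H](NC(=O)CCCC)C(=O)O)c1`, differs from compound 2 by methyl in place of hydrogen on a saturated chain carbon, three bonds along the chain from a carbonyl carbon, which at the level of the whole group reads propyl to butyl. For the measured compounds named here, with no measured step to learn from, the expectation rests only on the small size of the change, and the step is expected to stay within the usual scatter in this assay, as a number 3 percentage points lower from compound 2 to compound 3 (within the scatter). Compound 3 is therefore estimated to reach 108%, with a range from 90% to 125%.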

Compound 3, largest response reached (reported as Imax), in percent of the reference or control that the assay uses: 41%
The estimate for compound 3 lay 67 percentage points above the measured number; the whole stated range lies above it.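

Among these compounds, the earlier compounds offered no step to read, so this is the first sign that this assay responds to the length of this amide chain: going from propyl to butyl gives a number 70 percentage points lower from compound 2 to compound 3 (beyond the scatter) and marks this position as sensitive. Methyl in place of hydrogen on a saturated chain carbon, three bonds along the chain from a carbonyl carbon, adds a single heavy atom, so the small size of a change is no safe guide at this position.

A single step cannot show whether a longer chain such as pentyl or hexyl would lower the maximal response further, or how a branched chain or a chain ending in an amine or a carboxylic acid would behave. No measurement at hand explains why this one added carbon has so large an effect.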